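The compounds below may be only part of what the source reports. "The series", "measured", "known", "first", "only" and "open" are said of these compounds alone.

Measured compounds:
compound 1 `COc1cc2c(Oc3ccc(NC(=O)N/N=C/c4ccc(C(F)(F)F)cc4)cc3F)ccnc2cc1OCCCN1CCCCC1`, 630 nM in a functional assay on MKN-45 cells (Homo sapiens) for cytotoxicity, read by MTT assay, with a stated time of 72 h; a lower number here means a stronger inhibitor, a higher number a weaker inhibitor
compound 2 `COc1cc2c(Oc3ccc(NC(=O)N/N=C/c4ccc(F)cc4Cl)cc3F)ccnc2cc1OCCCN1CCCCC1`, 270 nM

In this set compound 2 holds the lowest of the two numbers; its nearest neighbour is compound 1, and the difference between them is a 2.3-fold lower number from compound 1 to compound 2 (0.37 log units; beyond the scatter). Compound 3 `COc1cc2c(Oc3ccc(NC(=O)N/N=C/c4cccs4)cc3F)ccnc2cc1OCCCN1CCCCC1` differs from compound 2 by thiophen-2-yl in place of 2-chloro-4-fluorophenyl on a carbon with a double bond to nitrogen. Among the compounds with values here, the only measured step, from compound 1 to compound 2, also changes the aromatic group on the carbon with a double bond to nitrogen, and it was modest. Within the data shown here, no step exchanges a six-membered ring for a five-membered one, so the expectation rests on that single modest step alone. Compound 3 is therefore expected to lie close to compound 2, at most a small step of a 1.5-fold higher number from compound 2 to compound 3 (0.17 log units; within the scatter), with an estimate of 400 nM and a likely range from 150 nM to 1200 nM.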

Compound 3, half-maximal inhibitory concentration: 740 nM
Compound 3: middle estimate off by 1.9-fold (0.27 log units), on the low side; the measured number falls inside the stated range.
By their numbers in this assay, from the lowest: compound 2; then compounds 1 and 3 (each within the scatter of the next).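

In this assay, thiophen-2-yl on this carbon with a double bond to nitrogen loses what 2-chloro-4-fluorophenyl had gained (a 2.7-fold higher number from compound 2 to compound 3 (0.44 log units; beyond the scatter)). Against 4-(trifluoromethyl)phenyl, the same exchange makes no readable difference (a 1.2-fold higher number from compound 1 to compound 3 (0.07 log units; within the scatter)), so among these three compounds only the 2-chloro-4-fluorophenyl group stands apart, and a five-membered ring is not itself set apart from every six-membered one. Nothing available here accounts for this. On these data alone, whether the chlorine or the fluorine carries the gain remains open. So does how a furan-2-yl or pyridin-3-yl ring would read at this place.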